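The compounds below may be only part of what the source reports. "The series", "measured", "known", "first", "only" and "open" are said of these compounds alone.

Measured compounds:
- compound 1 `Oc1ccc(-c2cc(-c3ccccn3)nc(-c3ccccc3Cl)c2)cc1`: "not determined" (no result reported)
- compound 2 `Oc1ccc(-c2cc(-c3ccccc3)nc(-c3ccccc3Cl)c2)cc1`: 5460 nM
- compound 3 `Oc1ccc(-c2cc(-c3ccc(Cl)cc3)nc(-c3cccnc3)c2)cc1`: 29300 nM

Three compounds share a common framework that carries a 4-hydroxyphenyl group and two further aromatic groups. For compound 1 no number was reported in a functional assay on T47D cells (Homo sapiens) for cytotoxicity, read by CCK-8 assay and cell counting, with a stated time of 2 days; a higher number here means a weaker inhibitor, a lower number a stronger inhibitor. In this assay compound 2 gives 5460 nM, and in this assay compound 3 gives 29300 nM. Of the two numbers available, compound 2 has the lower one, and the gap between compound 2 and compound 3 lies beyond the usual scatter, so compound 2 stands as the stronger inhibitor of the two. Compound 3 differs from compound 2 in more than one place, so its higher number cannot be tied to a single change.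

Compound 4 `Oc1ccc(-c2cc(-c3cccs3)nc(-c3ccccc3Cl)c2)cc1` is the next candidate. Relative to compound 2 the change is thiophen-2-yl in place of phenyl on an aromatic carbon, next to the ring nitrogen, meta to a 2-chlorophenyl group and meta to a 4-hydroxyphenyl group. Among the compounds with values here, no measured pair isolates this exchange, so there is no step to lean on. A five-membered aromatic group of this kind often replaces a phenyl with little consequence, so the estimated step of a 1.2-fold lower number from compound 2 to compound 4 (0.08 log units; within the scatter) from compound 2 is expected to stay within the scatter, with no clear direction. Compound 4 is therefore estimated at 4500 nM, within a range from 1500 nM to 15000 nM.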

Compound 4, half-maximal inhibitory concentration: 5870 nM
Compound 4: middle estimate off by 1.3-fold (0.12 log units), on the low side; the measured number falls inside the stated range.
By their numbers in this assay, from the lowest: compounds 2 and 4 (each within the scatter of the next); then compound 3.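

In this assay the change to thiophen-2-yl in place of phenyl, on an aromatic carbon next to the ring nitrogen, gives a 1.1-fold higher number from compound 2 to compound 4 (0.03 log units; within the scatter), so compound 2 and compound 4 cannot be told apart. Within the data shown here, this is the first pair that differs in one place, and it shows that at this position a five-membered aromatic ring with one hetero atom can stand in place of a six-membered aromatic ring of carbon only with no step beyond the scatter, though this rests on a single pair with the 2-chlorophenyl and 4-hydroxyphenyl groups held fixed. No measurement at hand offers an explanation for this result.

Going by these compounds, how a morpholine, an open-chain amine or a carboxylic acid would read at this position remains open, as does whether any group there can move the number beyond the scatter. In this assay compound 1, which carries a different aromatic group at the same position, gives "not determined" (no result reported), so it adds no second comparison with compound 2.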